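Extending the carboxy chain of compound 3

The source may report more compounds than this note shows. Statements on the series, on what has been measured and on what is new or still open speak of the compounds shown alone.

- compound 1 `COc1cc(C2CN(C(=O)c3cc(OCCO)ccn3)C2)ccc1OCc1ccc(C2CC2)cc1`: 64%
- compound 2 `COc1cc(C2CN(C(=O)c3cc(OC[C@H](O)CO)ccn3)C2)ccc1OCc1ccc(C2CC2)cc1`: 67%
- compound 3 `COc1cc(C2CN(C(=O)c3cc(OCCCC(=O)O)ccn3)C2)ccc1OCc1ccc(C2CC2)cc1`: 88%

These values come from an ADME assay on S9 fraction from liver (Mus musculus, strain CD-1) for metabolic stability, read by LC-MS, using NADPH, with stated times of 5 min and 60 min, tested at 5 uM; a higher number here means that more of the compound is left, a lower number that less of the compound is left. Compound 3 stands highest of the three, beyond the scatter of both others. The change to compound 4 `COc1cc(C2CN(C(=O)c3cc(OCCCC(C)(C)C(=O)O)ccn3)C2)ccc1OCc1ccc(C2CC2)cc1` is 1-carboxy-1-methylethyl in place of carboxy on a saturated chain carbon, three bonds along the chain from an oxygen on an aromatic ring. Two measured steps reach compound 3: a number 24 percentage points higher from compound 1 to compound 3 (beyond the scatter) and a number 21 percentage points higher from compound 2 to compound 3 (beyond the scatter). Both were modest, and both brought in the carboxy-bearing chain. For the measured compounds named here, neither tests what now enters, and compound 3 is the only measured compound with a carboxy group. Compound 4 keeps that group, so no step beyond the scatter is expected in this assay. The estimated step is a number 4 percentage points lower from compound 3 to compound 4 (within the scatter). For compound 4 the expected value is 84%, with an estimated range of 70% to 96%.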

Compound 4, percent of the compound remaining: 76%
Compound 4: middle estimate off by 8 percentage points, on the high side; low and high end bracket the measured number.
By their numbers in this assay, from the lowest: compounds 1, 2 and 4 (each within the scatter of the next, the first and the last beyond it); then compound 3.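

In this assay, for the compounds shown here, 1-carboxy-1-methylethyl in place of carboxy is the first change that keeps the carboxy group and alters the chain around it, and it gives a number 12 percentage points lower from compound 3 to compound 4 (beyond the scatter) at this position. Keeping the carboxy group therefore does not alone keep the number: compound 4 retains a number 12 percentage points higher from compound 1 to compound 4 (beyond the scatter) but shows only a number 9 percentage points higher from compound 2 to compound 4 (within the scatter) against the 1,2-dihydroxyethyl chain. Nothing measured here explains this change (no supporting evidence is available:).

From the compounds shown here alone, it remains open whether a single methyl on that carbon, or a shorter or longer carboxy chain, would stand nearer compound 3. An amine at the chain end is equally untested by these compounds.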